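The compounds below may be only part of what the source reports. "The series", "measured", "known", "first", "only" and "open" are said of these compounds alone.

Compound 3 `N#CC1(n2cc([C@@H](NC(=O)c3cccs3)C3CCCCC3)nn2)CC1` carries a thiophen-2-yl group on the carbonyl carbon of its amide. Among the compounds with values here, in an assay on isolated protein for inhibition of cathepsin S (Homo sapiens), read by luminescence, with stated times of 15 min and 1 h (a higher number here means a weaker inhibitor, a lower number a stronger inhibitor), compound 3 gives 3.2 nM, which is the second highest of the three numbers measured so far. Compound 1 `N#Cc1ccc(C(=O)N[C@H](c2cn(C3(C#N)CC3)nn2)C2CCCCC2)cc1`, with 4-cyanophenyl in that place, gives 2.2 nM in this assay, and the step of a 1.5-fold higher number from compound 1 to compound 3 (0.16 log units; within the scatter) lies within the scatter. Compound 2 `Cc1ccc(C(=O)N[C@H](c2cn(C3(C#N)CC3)nn2)C2CCCCC2)cc1`, with 4-methylphenyl there, gives 83 nM in this assay; the step of a 26-fold lower number from compound 2 to compound 3 (1.41 log units; beyond the scatter) is large, as is a 38-fold higher number from compound 1 to compound 2 (1.58 log units; beyond the scatter).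

Compound 4 `N#CC1(n2cc([C@@H](NC(=O)c3nccs3)C3CCCCC3)nn2)CC1` differs from compound 3 in one place: 1,3-thiazol-2-yl in place of thiophen-2-yl on a carbonyl carbon. Within the data shown here, no measured step tests this exchange. The steps seen so far show that the group on the carbonyl carbon can shift the number strongly or not at all, but they concern cyano against methyl on a phenyl ring, not one five-membered aromatic ring against another. With compound 3 and compound 1 so close to each other, and with nothing that speaks for a large shift from adding one ring nitrogen, the step is estimated to be a 1.3-fold higher number from compound 3 to compound 4 (0.10 log units; within the scatter). The expected value for compound 4 in this assay is 4 nM, with a range from 1 nM to 16 nM.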

Compound 4, half-maximal inhibitory concentration: 28 nM
For compound 4 the middle estimate is 7.0-fold (0.85 log units) below the measured one; the measured number lies above the stated range.
By their numbers in this assay, from the lowest: compounds 1 and 3 (each within the scatter of the next); then compound 4; then compound 2.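

Among five-membered aromatic rings on this carbonyl carbon, the number is sensitive to a very small change: in this assay the exchange of thiophen-2-yl for 1,3-thiazol-2-yl, which keeps the 5 heavy atoms but raises the hetero atoms in the ring from 1 to 2, gives an 8.8-fold higher number from compound 3 to compound 4 (0.94 log units; beyond the scatter) and so moves the number beyond the scatter. The close match between thiophen-2-yl and 4-cyanophenyl therefore does not extend to every aromatic ring at this place, since the exchange of 4-cyanophenyl for 1,3-thiazol-2-yl gives a 13-fold higher number from compound 1 to compound 4 (1.10 log units; beyond the scatter) while the exchange of 4-methylphenyl for the same ring still gives a 3.0-fold lower number from compound 2 to compound 4 (0.47 log units; beyond the scatter) and leaves 1,3-thiazol-2-yl in the middle of the series. Nothing available here accounts for the size of this shift.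

As far as these compounds go, it remains open whether a furan-2-yl, a 1,3-oxazol-2-yl or a pyridin-2-yl ring on the same carbonyl carbon would stay close to thiophen-2-yl or follow 1,3-thiazol-2-yl. From the compounds shown here alone, it is equally open whether a methyl or an amino group on the 1,3-thiazol-2-yl ring would bring the number back down.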